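Pyrazine and pyrimidine carboxamides on a fused quinoline core

A few compounds are considered here, and "the series" means these few. Any claim that something is new, unique, unknown or untested is made for them only; others in the source may bear on it.

Among the measured compounds shown here, in a functional assay on PANC-1 cells (Homo sapiens) for inhibition, read by MTT assay, with a stated time of 72 h (on this read-out lower numbers stand for stronger inhibition and higher numbers for weaker inhibition), compound 1 `Cc1cnc(C(=O)Nc2cc(F)cc3cccnc23)cn1` gives 2100 nM, the lowest of the two numbers measured so far. Compound 2 `O=C(Nc1cc(F)cc2cccnc12)c1ncccn1` carries a pyrimidin-2-yl in place of the 5-methylpyrazin-2-yl on the carbonyl carbon and in this assay gives 5300 nM; the step of a 2.5-fold higher number from compound 1 to compound 2 (0.40 log units; beyond the scatter) is modest but beyond the scatter.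

Compound 3 `Cc1cnc(C(=O)Nc2cc(OCCN)cc3cccnc23)cn1` keeps the 5-methylpyrazin-2-yl amide of compound 1 and changes the core instead: 2-aminoethoxy in place of fluoro on an aromatic carbon. For the measured compounds named here, no measured step touches this position; the single step from compound 1 to compound 2 concerns the acyl ring only and gives no guidance on the size or direction of this change. The expectation in this assay is therefore set near compound 1, with a wide band: for compound 3 the estimate is 2500 nM (range 700 nM to 9000 nM), a step of a 1.2-fold higher number from compound 1 to compound 3 (0.08 log units; within the scatter) that is expected to stay within the scatter.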

Compound 3, half-maximal inhibitory concentration: > 10000 nM
Compound 3: no number, only a limit; the forecaster's own chance of this, stated with the estimate: 5%; middle value at least 4.0-fold (0.60 log units) away from the limit.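

Among the compounds shown here, this is the first measured change on the core rather than on the acyl ring: in this assay, 2-aminoethoxy in place of fluoro gives an at least 4.7-fold higher number from compound 1 to compound 3 (0.67 log units; beyond the scatter), so the read-out responds to the group at this aromatic carbon, which the step between the two acyl rings could not show. For compound 3 the read-out is a limit of the assay and not a number: the limit of > 10000 nM in this assay, at which 1 of the 3 values shown sits. Going by these compounds, the step therefore gives a minimum size only, and its true size stays unknown.

The compounds shown do not separate the parts of the new group, so the terminal amine, the ether oxygen and the chain length remain open; a methoxy group, a 2-hydroxyethoxy group or a longer chain at this carbon would separate them. Also open, on these data alone, is whether the same change behaves alike with the pyrimidin-2-yl amide of compound 2.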